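Taking the Chloro Group off Compound 2

The compounds below may be only part of what the source reports. "The series", "measured", "known", "first", "only" and "open" are said of these compounds alone.

Of the compounds shown here, two have been measured so far in a functional assay on MOLT-4 cells (Homo sapiens) for inhibition, read by MTT assay, with a stated time of 48 h; on this read-out higher numbers stand for weaker inhibition and lower numbers for stronger inhibition. Compound 1 `O=C(/C=C/c1ccccc1Br)c1ccc[nH]1` gives 38000 nM, and compound 2 `O=C(/C=C/c1ccccc1Cl)c1ccco1` gives 25000 nM. These two values lie within the usual scatter of repeated measurements, so compound 2 stands level with compound 1 and neither can be ranked over the other.

Compound 3 `O=C(/C=C/c1ccccc1)c1ccco1` is still unmeasured. It differs from compound 2 by a single change: hydrogen in place of chloro on an aromatic carbon, which means hydrogen in place of chloro on an aromatic carbon. Among the measured compounds shown here, no measured pair of compounds isolates this kind of swap, so the data offer no direct guide to its effect in this assay. With no evidence for a large shift and no firm direction, the expectation is for no step beyond the scatter. For compound 3 the expected value is 30000 nM, with an estimated range from 11000 nM to 80000 nM. Put as a change, this estimate means an expected 1.2-fold higher number from compound 2 to compound 3 (0.08 log units; within the scatter).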

Compound 3, half-maximal inhibitory concentration: > 100000 nM
Compound 3 ended at the assay's limit; the forecaster's own chance of this, stated with the estimate: 15%; at least 3.3-fold (0.52 log units) between middle value and limit.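

In this assay compound 3 gives > 100000 nM, which is a limit of the assay and not a number. Replacing chloro with hydrogen on an aromatic carbon of a six-membered aromatic ring of carbon only, ortho to a group of 9 heavy atoms, gives an at least 4.0-fold higher number from compound 2 to compound 3 (0.60 log units; beyond the scatter), so this position is not indifferent to the change and the single chlorine atom counts for inhibition in these cells. This is the first pair of compounds to isolate one change, and the true size of the step stays unknown because the value of compound 3 sits at a limit: the limit of > 100000 nM in this assay, at which 1 of the 3 values shown sits.

The pair cannot tell whether chloro is specifically needed on this carbon or whether another group there, such as methyl, methoxy or an amine, would keep or even improve the inhibition seen with compound 2. It also leaves open whether chloro would have the same effect on another carbon of this ring, or whether the same swap would produce a similar step on the core of compound 1.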